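This account rests on a few compounds, and the source may have more. Where it says the series, first, only, none or still open, it means among the compounds named here.

Measured compounds:
compound 1 `N/C(=N\NC(=S)N1CCCC1)c1ccc(F)cn1`, which in a functional assay on A-375 cells (Homo sapiens) for cytotoxicity, read by MTT assay, with a stated time of 72 h, tested at 30 uM (a higher number here means more inhibition of growth at the concentration tested, a lower number less inhibition of growth), gives 83.2%
compound 2 `Cc1ccnc(/C(N)=N/NC(=S)N2CCSCC2)c1`, which in this assay gives 84.9%
compound 3 `N/C(=N\NC(=S)N1CCSCC1)c1ccccn1`, which in this assay gives 86%

Compound 3 holds the highest of the three numbers, but the other two lie within the scatter of it: compound 2 sits closest and compound 1 furthest, both by margins that mean nothing. Within the data shown here, the one step that can be followed, a number 1.1 percentage points higher from compound 2 to compound 3 (within the scatter), shows that removing a methyl from the aromatic ring leaves the readout unchanged. The next compound, compound 4 `N/C(=N\NC(=S)N1CCSCC1)c1ccc(F)cn1`, differs from compound 3 by fluoro in place of hydrogen on an aromatic carbon. Among the measured compounds shown here, no measured step covers this change directly. Compound 1 carries the same fluoro on the same ring with a different amine ring, and its value and that of compound 3 are within the scatter of each other, which gives no sign that the fluoro shifts the number. The step from compound 2 to compound 3 likewise shows this ring tolerating a change without effect. The account therefore expects no movement beyond the scatter in this assay, and the step of a number 1 percentage points lower from compound 3 to compound 4 (within the scatter) is estimated to be flat. Compound 4 is expected to give 85%, with a range from 77% to 92%.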

Compound 4, percent growth inhibition at one concentration: 78.7%
Estimate against measurement, compound 4: 6.3 percentage points above; low and high end bracket the measured number.
By their numbers in this assay, from the lowest: compounds 4, 1, 2 and 3 (each within the scatter of the next).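

The fluoro group, on an aromatic carbon two atoms from the ring nitrogen and para to a large group, now has a direct test with the thiomorpholin-4-yl group held fixed: in this assay the step, a number 7.3 percentage points lower from compound 3 to compound 4 (within the scatter), gives no readable effect of this change at this position. With the fluoro held instead, the amine ring gets its first direct comparison, and a number 4.5 percentage points lower from compound 1 to compound 4 (within the scatter), for thiomorpholin-4-yl in place of pyrrolidin-1-yl on a thiocarbonyl carbon, likewise gives no separation, so neither change can be told from the scatter of repeated measurements. Nothing at hand bears on the cause of these small differences.

On these data alone, what remains open is whether a chloro, methoxy or amino group on this same aromatic carbon would move the number beyond the scatter. As far as these compounds go, it is also open whether a piperidin-1-yl or morpholin-4-yl group on the thiocarbonyl carbon would separate from thiomorpholin-4-yl and pyrrolidin-1-yl, and whether these compounds would differ at any other concentration.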